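Amide aryl exchange in a shared-core cytotoxicity series

The compounds below may be only part of what the source reports. "The series", "measured", "known", "first", "only" and "open" are said of these compounds alone.

The series is followed in an ADME assay on MT4 cells (Homo sapiens) for cytotoxicity, read by MTT assay; a higher number here means that more compound is tolerated, a lower number that less compound is tolerated. Of the compounds shown here, two carry numbers so far. Compound 1, `COC(=O)c1sccc1NC(=O)CSc1nncnc1-c1ccccc1Cl`, gives 105000 nM in this assay. Compound 2, `COC(=O)c1ccc(NC(=O)CSc2nncnc2-c2ccccc2Cl)c(Br)c1`, gives 59000 nM in this assay. Compound 1 stands alongside compound 2: the two numbers lie within the usual scatter of each other, so no order can be read between them, and both sit at the high end of what the assay reads. For the measured compounds named here, no pair of measured compounds differs in only one place, so no single-change step is available as a guide.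

Compound 3, `O=C(CSc1nncnc1-c1ccccc1Cl)Nc1ccccn1`, is not yet measured. It differs from compound 1 by pyridin-2-yl in place of 2-(methoxycarbonyl)thiophen-3-yl on an amide-type nitrogen. The change sits wholly on the amide-type nitrogen; the shared core is untouched. Going by the values given here, with only two measured compounds, both of which hold tolerated numbers within the scatter of each other, the expected step from compound 1 to compound 3 is none beyond the scatter, so a 1.2-fold lower number from compound 1 to compound 3 (0.07 log units; within the scatter) is the expected outcome. Compound 3 is therefore estimated to give 90000 nM in this assay, with a range from 40000 nM to 200000 nM.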

Compound 3, half-maximal cytotoxic concentration: 172000 nM
For compound 3 the middle estimate is 1.9-fold (0.28 log units) below the measured one; the measured number falls inside the stated range.
By their numbers in this assay, from the lowest: compounds 2, 1 and 3 (each within the scatter of the next, the first and the last beyond it).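

For the compounds shown here, the first single-change step, read in this assay, is a 1.6-fold higher number from compound 1 to compound 3 (0.21 log units; within the scatter), so the amide-type nitrogen accepts an exchange of its whole aryl group without a readable shift in the number. The exchange is not a small one: pyridin-2-yl, with 6 heavy atoms, one six-membered aromatic ring and no sulfur or methoxycarbonyl, enters in place of 2-(methoxycarbonyl)thiophen-3-yl, with 9 heavy atoms and one five-membered aromatic ring, so neither the methoxycarbonyl group nor the thiophene ring is needed to hold the number at this level in compound 3. No measurement bearing on this step is available to explain it.

On these data alone, it remains open whether the number stays at this level with a group on the amide-type nitrogen that lacks an aromatic ring, such as cyclohexyl or a short alkyl chain, or with a pyridine ring carrying a carboxylic acid or an amine. Going by these compounds alone, a change at the shared core is also still untested in these compounds, so the single step says nothing about how far the core itself sets the number.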